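This account rests on a few compounds, and the source may have more. Where it says the series, first, only, none or still open, it means among the compounds named here.

Compound 1 `Cc1nnc(SCC(=O)c2ccc(Cl)cc2)n1N1C(=O)c2ccccc2C1=O` and compound 2 `Cc1ccc(C(=O)CSc2nnc(C)n2N2C(=O)c3ccccc3C2=O)cc1` share one core and differ at a single aromatic carbon. In a functional assay on PC-3M cells (Homo sapiens) for cytotoxicity, read by MTT assay, with a stated time of 48 h (a higher number here means a weaker inhibitor, a lower number a stronger inhibitor), compound 1 gives only the limit > 200000 nM. In this assay compound 2 also gives only the limit > 200000 nM. The step that the two limits leave unreadable from compound 1 to compound 2 stays unreadable because of the limit of > 200000 nM in this assay, at which 2 of the 2 values shown sit. Compound 3 `CSc1nnc(C)n1N1C(=O)c2ccccc2C1=O` differs from compound 2 by hydrogen in place of (4-methylphenyl)carbonyl on a saturated chain carbon bound to a sulfur. Within the data shown here, no measured step bears on this change, as the only step is itself unreadable. The expected step is a step that the limit leaves unreadable from compound 2 to compound 3. Compound 3 is estimated at 300000 nM, with a range from 100000 nM to 1000000 nM, most likely again reported only as a limit.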

Compound 3, half-maximal inhibitory concentration: > 200000 nM
Compound 3 was reported as a limit; the forecaster's own chance of this, stated with the estimate: 85%; the middle value is on the limit's open side.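

Compound 3 adds no readable step from compound 1 or compound 2, because all three values are limits: the limit of > 200000 nM in this assay, at which 3 of the 3 values shown sit.

The compounds shown leave open whether any change to the shared core gives a measurable value in this assay.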